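Adding a Sulfoxide Group to Compound 1

This account rests on a few compounds, and the source may have more. Where it says the series, first, only, none or still open, it means among the compounds named here.

Three compounds have been measured in a functional assay (Homo sapiens) for inhibition (a higher number here means a weaker inhibitor, a lower number a stronger inhibitor), so far:

- compound 1 `CSc1ccccc1CSc1nc(-c2ccc(F)cc2)c(-c2ccncc2)[nH]1` gives 6700 nM
- compound 2 `C[S+]([O-])c1ccc(CCCSc2nc(-c3ccc(F)cc3)c(-c3ccncc3)[nH]2)cc1` gives 180 nM
- compound 3 `C[S+]([O-])c1ccc(CSc2nc(-c3ccccc3)c(-c3ccncc3)[nH]2)cc1` gives 840 nM

Compound 1 has the highest number of the three and is the weakest inhibitor among them. Its gaps to compound 3, the nearest, and to compound 2, the furthest, both lie beyond the usual scatter. Within the data shown here, compound 2 and compound 3 each carry a sulfoxide that compound 1 lacks, but they also differ from compound 1 elsewhere, so no measured pair isolates a single change.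

Compound 4 `C[S+]([O-])c1cc(CSc2nc(-c3ccc(F)cc3)c(-c3ccncc3)[nH]2)ccc1O` keeps the core of compound 1 and has a new group on a saturated chain carbon bound to a sulfur (a group of 10 heavy atoms (7 carbon, 2 oxygen, 1 sulfur; one six-membered aromatic ring of carbon only) in place of a group of 8 heavy atoms (7 carbon, 1 sulfur; one six-membered aromatic ring of carbon only), on a saturated chain carbon bound to a sulfur). That group also holds a sulfoxide. Among the measured compounds shown here, with no direct step available, the expectation rests on the two measured sulfoxides, compound 2 (180 nM) and compound 3 (840 nM). The expected step is a fall in the number, beyond the scatter (an 11-fold lower number from compound 1 to compound 4 (1.05 log units; beyond the scatter)). For the measured compounds named here, the new group has no measured precedent, so the expected range is wide. In this assay compound 4 is expected at 600 nM (range 120 nM to 2500 nM).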

Compound 4, half-maximal inhibitory concentration: 2300 nM
Compound 4: the middle estimate sits 3.8-fold (0.58 log units) below what was measured; measured number inside the range.
By their numbers in this assay, from the lowest: compound 2; then compound 3; then compound 4; then compound 1.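

In this assay, among these compounds, the exchange on a saturated chain carbon bound to a sulfur provides the first step that can be read in one place: 2-(methylsulfanyl)phenyl gives way to a group of 10 heavy atoms holding a sulfoxide and a hydroxyl group, with a 2.9-fold lower number from compound 1 to compound 4 (0.46 log units; beyond the scatter). The step is modest but lies beyond the scatter, so a change confined to this group does move the number in the direction of stronger inhibition, though it cannot be divided between the sulfoxide and the hydroxyl group, and the entering group also has 1 hydrogen-bond donor where the leaving group has 0. Nothing measured here offers an explanation for the step.

As far as these compounds go, whether a sulfoxide without the hydroxyl group, or an amine or a carboxylic acid at the same place, would give a lower number remains open. Compound 2 and compound 3 differ from compound 4 in more than one place, so those steps cannot be read, and the separate contributions of chain length and of the fluorine on the other ring stay unresolved.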